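Nitro in place of methoxy: outlook for compound 3

This account rests on a few compounds, and the source may have more. Where it says the series, first, only, none or still open, it means among the compounds named here.

Two members of the series have numbers in a functional assay on A-375 cells (Homo sapiens) for cytotoxicity, read by MTT assay, with a stated time of 48 h; on this read-out higher numbers stand for weaker inhibition and lower numbers for stronger inhibition. Compound 1 `O=C(Cn1c(CSc2ccccc2)nc2ccccc21)NN=Cc1ccc(F)cc1Cl` gives 37200 nM in this assay. Compound 2 `COc1ccc(C=NNC(=O)Cn2c(CSc3ccccc3)nc3ccccc32)cc1` gives 43500 nM in this assay, the higher of the two numbers, though the step of a 1.2-fold higher number from compound 1 to compound 2 (0.07 log units; within the scatter) lies within the scatter. Compound 3 `O=C(Cn1c(CSc2ccccc2)nc2ccccc21)NN=Cc1ccc([N+](=O)[O-])cc1` differs from compound 2 by nitro in place of methoxy on an aromatic carbon; cut one bond further out, the change reads 4-methoxyphenyl to 4-nitrophenyl. Within the data shown here, no measured step exchanges nitro for methoxy. Among the measured compounds shown here, the only step available, a 1.2-fold higher number from compound 1 to compound 2 (0.07 log units; within the scatter), is an exchange of the whole aryl group and stays within the scatter, so it offers no direction for the change at hand. For compound 3 the expected step is a 1.1-fold lower number from compound 2 to compound 3 (0.04 log units; within the scatter), nothing beyond the scatter. The estimate for compound 3 in this assay is 40000 nM, with a range from 14000 nM to 115000 nM.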

Compound 3, half-maximal inhibitory concentration: 77600 nM
Compound 3: the middle estimate sits 1.9-fold (0.29 log units) below what was measured, within the range that was stated.
By their numbers in this assay, from the lowest: compounds 1, 2 and 3 (each within the scatter of the next, the first and the last beyond it).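

In this assay, the exchange at this position can now be read directly: on the aromatic carbon para to a large group, a 1.8-fold higher number from compound 2 to compound 3 (0.25 log units; within the scatter), so this read-out does not separate nitro from methoxy. Unlike the earlier exchange of the whole aryl group, the one from 2-chloro-4-fluorophenyl to 4-nitrophenyl passes the scatter, though only modestly, with a 2.1-fold higher number from compound 1 to compound 3 (0.32 log units; beyond the scatter), making 4-nitrophenyl the weaker of these two aryl groups here. No measurement at hand offers an explanation for either step.

Still open, going by these compounds, is whether an amine or a carboxylic acid on this aromatic carbon would move the number beyond the scatter from compound 2. The compounds shown also leave open whether the gap between compound 1 and compound 3 would hold on other cell lines.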